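Dihydroxyphenyl for Dichlorophenyl: What to Expect

A few compounds are considered here, and "the series" means these few. Any claim that something is new, unique, unknown or untested is made for them only; others in the source may bear on it.

Three compounds share one core and differ only in the group attached to the carbon with a double bond to nitrogen. In a functional assay on HT-29 cells (Homo sapiens) for cytotoxicity, read by MTT assay, with a stated time of 72 h (a lower number here means a stronger inhibitor, a higher number a weaker inhibitor), compound 1 `CN(C)CCn1cnnc1-c1cc(Oc2ccc(NC(=O)N/N=C/c3ccc(Cl)cc3Cl)cc2F)ccn1` gives 390 nM. Compound 2 `CN(C)CCn1cnnc1-c1cc(Oc2ccc(NC(=O)N/N=C/c3c(O)ccc4ccccc34)cc2F)ccn1` gives 670 nM in this assay, and compound 3 `CN(C)CCn1cnnc1-c1cc(Oc2ccc(NC(=O)N/N=C/c3ccc(F)cc3Cl)cc2F)ccn1` gives 510 nM. Compound 1 has the lowest of the three numbers, but both steps away from it stay within the scatter: a 1.7-fold higher number from compound 1 to compound 2 (0.24 log units; within the scatter) and a 1.3-fold higher number from compound 1 to compound 3 (0.12 log units; within the scatter).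

Compound 4 `CN(C)CCn1cnnc1-c1cc(Oc2ccc(NC(=O)N/N=C/c3ccc(O)cc3O)cc2F)ccn1` has not yet been measured. It differs from compound 1 in one place: 2,4-dihydroxyphenyl in place of 2,4-dichlorophenyl on a carbon with a double bond to nitrogen. For the measured compounds named here, two measured steps bear on this. The move to compound 2 brought a hydroxyl onto the aromatic group, and the move to compound 3 exchanged one halogen for another; in both cases the number stayed within the scatter. Both say that the group on this carbon has so far mattered little. Replacing both chlorines with hydroxyls is a larger change than either, so a modest shift toward a higher number seems the more likely outcome, but nothing measured here supports a step beyond the scatter. The expected step is a 1.9-fold higher number from compound 1 to compound 4 (0.28 log units; within the scatter). Compound 4 is therefore estimated at 750 nM, with a range from 300 nM to 2200 nM.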

Compound 4, half-maximal inhibitory concentration: 52600 nM
Compound 4: the middle estimate sits 70-fold (1.85 log units) below what was measured; the whole stated range lies below it.
By their numbers in this assay, from the lowest: compounds 1, 3 and 2 (each within the scatter of the next); then compound 4.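

The group on this carbon can matter a great deal after all: in this assay the change to 2,4-dihydroxyphenyl gives a 130-fold higher number from compound 1 to compound 4 (2.13 log units; beyond the scatter) and sets compound 4 apart from the other two as well, with a 100-fold higher number from compound 3 to compound 4 (2.01 log units; beyond the scatter) and a 79-fold higher number from compound 2 to compound 4 (1.89 log units; beyond the scatter) as the steps that show it. The group that leaves and the group that enters have the same count of heavy atoms and the same aromatic ring, so a change in atoms alone, with hydrogen-bond donors and acceptors entering where there were none, is enough for a step of this size. A hydroxyl on the group does not always go with such a step, as compound 2 carries one on its 2-hydroxynaphthalen-1-yl group and stays within the scatter of compound 1.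

Still open, on these data alone, is whether a phenyl group with one hydroxyl and one chlorine, or with two methoxy groups, would stay with compounds 1, 2 and 3 or fall with compound 4. Why compound 4 stands so far from the others also stays open, as nothing given here explains it.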